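The source may report more compounds than this note shows. Statements on the series, on what has been measured and on what is new or still open speak of the compounds shown alone.

In a functional assay on HeLa cells (Homo sapiens) for antiproliferative activity, read by MTT assay, with a stated time of 48 h (on this read-out lower numbers stand for stronger inhibition and higher numbers for weaker inhibition), compound 1 `N#Cc1cccc(Nc2ncnc3cc(NC(=O)/C=C/c4ccccc4)sc23)c1` gives 7220 nM and compound 2 `C#Cc1cccc(Nc2ncnc3sc(NC(=O)/C=C/c4ccccc4)cc23)c1` gives 4640 nM. Among the measured compounds shown here, these two values lie within the usual scatter of repeated measurements, so compound 1 stands level with the only other compound measured so far. Compound 3 `O=C(/C=C/c1ccccc1)Nc1cc2ncnc(Nc3ccc(Cl)c(Cl)c3)c2s1` has not yet been measured. It differs from compound 1 in one place: 3,4-dichlorophenyl in place of 3-cyanophenyl on a nitrogen on an aromatic ring. In words, 3,4-dichlorophenyl stands in place of 3-cyanophenyl on a nitrogen on an aromatic ring. For the measured compounds named here, no measured pair of compounds shows what a change at this place does, so no step beyond the scatter is expected in this assay. The estimated step is a 1.6-fold lower number from compound 1 to compound 3 (0.21 log units; within the scatter). For compound 3, the expected value is 4500 nM, with an estimated range from 1500 nM to 13000 nM.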

Compound 3, half-maximal inhibitory concentration: 10700 nM
Compound 3: the middle estimate sits 2.4-fold (0.38 log units) below what was measured; measured number inside the range.
By their numbers in this assay, from the lowest: compounds 2, 1 and 3 (each within the scatter of the next, the first and the last beyond it).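

Among the compounds shown here, this is the first pair of compounds that shows what a change at this place does. In this assay, putting 3,4-dichlorophenyl in place of 3-cyanophenyl on the nitrogen gives a 1.5-fold higher number from compound 1 to compound 3 (0.17 log units; within the scatter), so the two compounds stand level: a ring carrying a nitrile and a ring carrying two chlorines, each with the same count of heavy atoms, read alike here. Nothing measured here bears on why they read alike.

A single pair cannot show whether any group at this place would move the number beyond the scatter, or whether this place matters little in this assay. A phenyl ring carrying an amine or a carboxylic acid, or a longer alkyl chain in place of the ring, would test that more widely.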